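Methyl Groups on a Shared Core: Compounds 1 to 4

The source may report more compounds than this note shows. Statements on the series, on what has been measured and on what is new or still open speak of the compounds shown alone.

Measured so far:
compound 1, `Cc1ccnc2nc(-c3cccc(Cl)c3)cc(O)c12`, 158 nM
compound 2, `Oc1cc(-c2ccc3ccccc3c2)nc2ncccc12`, 8130 nM
compound 3, `Cc1cc(C)c2c(O)cc(-c3cccc(Cl)c3)nc2n1`, 347 nM

Of the compounds shown here, three have been tested in a functional assay on cells (Tumor Cell line, Homo sapiens) for antiproliferative activity; a lower number here means a stronger inhibitor of growth, a higher number a weaker inhibitor of growth. Compound 1 gives 158 nM, and compound 3, which carries one more methyl group, gives 347 nM. The change between them is methyl in place of hydrogen on an aromatic carbon, and it produces a 2.2-fold higher number from compound 1 to compound 3 (0.34 log units; beyond the scatter). Compound 2 stands at the top of the three numbers with 8130 nM; the difference between its core and the core of compound 1 is not broken down here.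

Compound 4, `Cc1cnc2nc(-c3ccc4ccccc4c3)cc(O)c2c1`, has not yet been measured. It differs from compound 2 by methyl in place of hydrogen on an aromatic carbon. Within the data shown here, this is the same kind of change as the one from compound 1 to compound 3, not the same change: in compound 3 the methyl enters next to the ring nitrogen and meta to a methyl group, whereas in compound 4 it enters two atoms from the ring nitrogen and there is no second methyl group on that ring.

Among the measured compounds shown here, on that basis, a step of similar size is expected, namely a 1.8-fold higher number from compound 2 to compound 4 (0.27 log units; within the scatter) in this assay, because the only precedent is a 2.2-fold higher number from compound 1 to compound 3 (0.34 log units; beyond the scatter). Compound 4 is therefore estimated at 15000 nM, with a likely range from 5000 nM to 40000 nM. Only the measurement can tell whether the modest rise seen between compound 1 and compound 3 carries over to the core of compound 2.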

Compound 4, concentration for 50% growth inhibition: 741 nM
The estimate for compound 4 lay 20-fold (1.31 log units) above the measured number; measured number below the stated range.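

In this assay, methyl in place of hydrogen on an aromatic carbon gives an 11-fold lower number from compound 2 to compound 4 (1.04 log units; beyond the scatter), so this step runs in the opposite direction to the earlier one, and the two cannot be read as a single effect of the change: the same change on two cores in this assay, a 2.2-fold higher number (0.34 log units; beyond the scatter) from compound 1 to compound 3 and an 11-fold lower number (1.04 log units; beyond the scatter) from compound 2 to compound 4, 24-fold (1.38 log units) apart, beyond the scatter of two such steps

This shows that in this series the name of the change alone does not predict the size or the direction of the step on the other core. Among these compounds, it does not show what sets the two steps apart, since only two such steps are available and they differ both in the core and in the place where the methyl enters, so these compounds cannot separate the one from the other.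

The compounds shown leave open whether a methyl group two atoms from the ring nitrogen would also lower the number on the core of compound 1, a comparison that would test place and core separately. They also leave open how a group other than methyl at that place, such as an ethyl chain, a methoxy group or an amine, would compare with compound 4 in this assay.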